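The source may hold more compounds than are shown below. What is called first, only, known or untested is meant among the compounds shown, and "the series" means these compounds.

Measured so far in an assay on Sf9 cells for inhibition of protein deacetylase HDAC6 (Homo sapiens), read by fluorescence, with a stated time of 90 min; on this read-out higher numbers stand for weaker inhibition and lower numbers for stronger inhibition:
- compound 1 `O=C(NO)c1ccc(Cn2c(=O)c(OCc3ccccc3)c(-c3ccccc3)c3ccccc32)cc1`: 84.5 nM
- compound 2 `Cn1c(=O)c(OCc2ccc(C(=O)NO)cc2)c(-c2ccccc2)c2ccccc21`: 519 nM

Compound 2 stands highest of the two numbers. Its nearest neighbour is compound 1, whose number is lower by a gap that lies beyond the scatter. Among the measured compounds shown here, the two compounds differ in more than one place, so their values show only that compound 1 is the stronger inhibitor of the pair in this assay.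

Compound 3 `O=C(NO)c1ccc(COc2c(-c3ccccc3)c3ccccc3n(Cc3ccncc3)c2=O)cc1` is not yet measured. Relative to compound 2 the change is pyridin-4-yl in place of hydrogen on a saturated chain carbon bound to an aromatic nitrogen. For the measured compounds named here, no measured pair isolates this change. Compound 1 carries a larger substituent on the same aromatic nitrogen and gives 84.5 nM, which points loosely toward the larger substituent being tolerated. The step expected a 1.5-fold lower number from compound 2 to compound 3 (0.17 log units; within the scatter) is small and downward, possibly not beyond the scatter. Compound 3 is estimated at 350 nM, in the range 120 nM to 1000 nM.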

Compound 3, half-maximal inhibitory concentration: 84.1 nM
Compound 3: middle estimate off by 4.2-fold (0.62 log units), on the high side; measured number outside the range, below it.
By their numbers in this assay, from the lowest: compounds 3 and 1 (each within the scatter of the next); then compound 2.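

In this assay, among the compounds shown here, going from methyl to (pyridin-4-yl)methyl on the aromatic nitrogen gives a 6.2-fold lower number from compound 2 to compound 3 (0.79 log units; beyond the scatter) as the first step at this position that isolates a single change. The substituent at this position therefore bears on inhibition, and pyridin-4-yl on the saturated chain carbon goes with stronger inhibition than hydrogen there. Nothing at hand gives a reason for this step.

The compounds shown leave open whether the step belongs to the ring nitrogen of pyridin-4-yl or to an aromatic ring as such, a question that a plain phenyl ring on the same carbon would address. Also open, going by these compounds, is how pyridin-3-yl, pyridin-2-yl, an amine or a longer chain at this position would read.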